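Working notes: a larger aryl variant of compound 1

The compounds below may be only part of what the source reports. "The series", "measured", "known", "first", "only" and "open" are said of these compounds alone.

compound 1 `O=C(Nc1cc2cc[nH]c(=O)c2cc1Cl)C1CNCC1c1ccc(F)cc1` — 9 nM
compound 2 `O=C(Nc1cc2cc[nH]c(=O)c2cc1Cl)C1CNCCC1c1ccccc1` — 6 nM

In an assay on isolated protein for inhibition of Rho-associated protein kinase 2 (Homo sapiens), read by a luciferase reporter (a higher number here means a weaker inhibitor, a lower number a stronger inhibitor), compound 1 gives 9 nM. Compound 2 gives 6 nM, and the gap between compound 1 and compound 2 is within the scatter, so the two sit together. Compound 3 `CC(C)(C)c1cccc(C2CNCC2C(=O)Nc2cc3cc[nH]c(=O)c3cc2Cl)c1` differs from compound 1 by 3-(tert-butyl)phenyl in place of 4-fluorophenyl on a saturated ring carbon. Among the measured compounds shown here, no measured pair shows this change, so its direction is open. For compound 3 the estimate is 15 nM, with a range from 4 nM to 60 nM. The step from compound 1 to compound 3 is expected to be a 1.7-fold higher number from compound 1 to compound 3 (0.22 log units; within the scatter), a modest weakening at most, not clearly beyond the scatter.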

Compound 3, half-maximal inhibitory concentration: 11 nM
Compound 3: the middle estimate sits 1.4-fold (0.13 log units) above what was measured; low and high end bracket the measured number.
By their numbers in this assay, from the lowest: compounds 2, 1 and 3 (each within the scatter of the next).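

In this assay the step from 4-fluorophenyl to 3-(tert-butyl)phenyl on this saturated ring carbon is a 1.2-fold higher number from compound 1 to compound 3 (0.09 log units; within the scatter) and so shows that this position tolerates an aryl group of 10 heavy atoms in place of one of 7. No available data offer an explanation for this tolerance.

The compounds shown do not separate the loss of the fluorine from the gain of the tert-butyl group. They also leave open whether an aryl ring bearing an amine or a carboxylic acid, or cyclohexyl in place of the aryl ring, would stay within the scatter of compound 1.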